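A few compounds are considered here, and "the series" means these few. Any claim that something is new, unique, unknown or untested is made for them only; others in the source may bear on it.

Measured in a functional assay on HT-29 cells (Homo sapiens) for inhibition, read by MTT assay, with a stated time of 48 h; a lower number here means a stronger inhibitor, a higher number a weaker inhibitor:
- Compound 1 `COc1ccc(C/N=C2\NC(=O)/C(=C3\CCNC(=O)c4[nH]ccc43)S2)cc1`: 11500 nM
- Compound 2 `O=C1N/C(=N\Cc2ccc(C(F)(F)F)cc2)S/C1=C1/CCNC(=O)c2[nH]ccc21`: > 50000 nM
- Compound 3 `Cc1ccc(C/N=C2\NC(=O)/C(=C3\CCNC(=O)c4[nH]ccc43)S2)cc1`: 6830 nM

Compound 3 stands at 6830 nM in this assay and cannot be separated from its nearest neighbour: a 1.7-fold lower number from compound 1 to compound 3 (0.23 log units; within the scatter). Compound 2 gives > 50000 nM, which is a limit of the assay and not a number. The series still shows an at least 4.3-fold higher number from compound 1 to compound 2 (0.63 log units; beyond the scatter).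

Compound 4 `CC(C)(C)c1ccc(C/N=C2\NC(=O)/C(=C3\CCNC(=O)c4[nH]ccc43)S2)cc1` carries tert-butyl in place of methyl on an aromatic carbon. Among the measured compounds shown here, no measured compound has tert-butyl at this place, so the guidance is indirect. Methoxy and methyl there read alike, while the one other replacement of methyl, seen in reverse as an at least 7.3-fold lower number from compound 2 to compound 3 (0.86 log units; beyond the scatter), is beyond the scatter. Some rise in the number is therefore expected, though the evidence is too thin to expect a large one. The expected change is a 1.5-fold higher number from compound 3 to compound 4 (0.17 log units; within the scatter), which would leave the middle of the estimate within the scatter. The estimate for compound 4 is 10000 nM, with an expected range from 3000 nM to 40000 nM.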

Compound 4, half-maximal inhibitory concentration: 43400 nM
The estimate for compound 4 lay 4.3-fold (0.64 log units) below the measured number, and the stated range ends below it.
By their numbers in this assay, from the lowest: compounds 3 and 1 (each within the scatter of the next); then compound 4. At a limit, above all of these: compound 2.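

In this assay, this place, para to a large group, does not treat all carbon substituents alike: tert-butyl in place of methyl gives a modest step: a 6.4-fold higher number from compound 3 to compound 4 (0.80 log units; beyond the scatter). Tert-butyl in place of methoxy also gives a modest step: a 3.8-fold higher number from compound 1 to compound 4 (0.58 log units; beyond the scatter), so these are the first steps beyond the scatter at this place that join two measured numbers and not a number and a limit. The remaining step is an at least 1.1-fold lower number from compound 2 to compound 4 (0.06 log units; that floor lies within the scatter) and gives only a floor. Compound 2 remains at a limit and not a number: the limit of > 50000 nM in this assay, at which 1 of the 4 values shown sits.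

The compounds shown leave open how an amine or a carboxylic acid at this place would read, and whether a straight butyl chain would track tert-butyl or methyl. They also leave open whether the same step would hold with an ethyl or isopropyl group at this place.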